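Two Compounds Level, and a Thiophene Swap to Estimate

The source may report more compounds than this note shows. Statements on the series, on what has been measured and on what is new or still open speak of the compounds shown alone.

Compound 1 `Cc1ccc(/C=C(/SCc2ccc(Cl)cc2Cl)C(=O)c2ccc(Cl)cc2)s1`: 50000 nM
Compound 2 `O=C(/C(=C\c1ccc(O)cc1O)SCc1ccc(Cl)cc1)c1ccc(Cl)cc1`: 50000 nM

Both compounds were measured in a functional assay on DU-145 cells (Homo sapiens) for inhibition, read by trypan blue exclusion, with a stated time of 96 h; on this read-out lower numbers stand for stronger inhibition of growth and higher numbers for weaker inhibition of growth. There, compound 2 gives 50000 nM, which is level with compound 1 and within the usual scatter.

Compound 3 `Cc1ccc(/C=C(/SCc2ccc(Cl)cc2)C(=O)c2ccc(Cl)cc2)s1` changes one group of compound 2: 5-methylthiophen-2-yl in place of 2,4-dihydroxyphenyl on a double-bonded chain carbon bound to a double-bonded chain carbon. Put simply, 5-methylthiophen-2-yl stands in place of 2,4-dihydroxyphenyl on a double-bonded chain carbon bound to a double-bonded chain carbon.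

Going by the values given here, no measured pair shows the effect of this change on its own, so the evidence is indirect. Compound 1 also carries 5-methylthiophen-2-yl and gives 50000 nM, so no step beyond the scatter is expected in this assay. The expected step is a 1.3-fold lower number from compound 2 to compound 3 (0.10 log units; within the scatter). Compound 3 is estimated at 40000 nM, with an expected range from 12000 nM to 60000 nM.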

Compound 3, concentration for 50% growth inhibition: 50000 nM
The estimate for compound 3 lay 1.3-fold (0.10 log units) below the measured number; the range from low to high includes it.
By their numbers in this assay, from the lowest: compounds 1, 2 and 3 (each within the scatter of the next).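

In this assay, the swap of 2,4-dihydroxyphenyl for 5-methylthiophen-2-yl on a double-bonded chain carbon bound to a double-bonded chain carbon can now be read directly, and it gives no change at the digits printed from compound 2 to compound 3 (within the scatter). Hydrogen in place of chloro on an aromatic carbon, a second change that could not be read before, gives no change at the digits printed from compound 1 to compound 3 (within the scatter). So neither change separates these compounds in this assay, even though the swap removes 2 hydrogen-bond donors, and nothing available explains this result.

Still open, as far as these compounds go, is whether any group at this place would lower the number, for example an amine or a carboxylic acid on the ring in place of the methyl of 5-methylthiophen-2-yl. Also open, from the compounds shown here alone, is whether a longer chain in place of the benzyl-type link on sulfur would do so.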